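The compounds below may be only part of what the source reports. "The series", "measured", "known", "first", "only" and "open" are said of these compounds alone.

Working notes on the series in a functional assay on HeLa cells (Homo sapiens) for cytotoxicity, read by MTT assay, with a stated time of 48 h; a lower number here means a stronger inhibitor, a higher number a weaker inhibitor: compound 1 (`O=C(O)CN1C(=O)/C(=C/c2nc3ccccc3n2Cc2ccc([N+](=O)[O-])cc2)SC1=S`) reads 18600 nM, compound 2 (`O=C(O)CN1C(=O)/C(=C/c2nc3ccccc3n2Cc2ccc(F)cc2)SC1=S`) reads 13900 nM and compound 3 (`O=C(O)CN1C(=O)/C(=C/c2nc3ccccc3n2Cc2ccc(Cl)cc2)SC1=S`) reads 8720 nM. Compound 3 stands level with compound 2 within the scatter and is separated only from compound 1, with a 2.1-fold lower number from compound 1 to compound 3 (0.33 log units; beyond the scatter) as a modest step. Both a 1.3-fold lower number from compound 1 to compound 2 (0.13 log units; within the scatter) and a 1.6-fold lower number from compound 2 to compound 3 (0.20 log units; within the scatter) stay within the scatter.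

Compound 4 (`O=C(O)CN1C(=O)/C(=C/c2nc3ccccc3n2Cc2ccc(F)cc2F)SC1=S`) has 2,4-difluorophenyl in place of 4-chlorophenyl on a saturated chain carbon bound to an aromatic nitrogen. The closest evidence is a 1.6-fold lower number from compound 2 to compound 3 (0.20 log units; within the scatter) for chloro in place of fluoro, which here runs the other way. Among the measured compounds shown here, no measured compound carries two fluoro groups, so that part of the change is untested. A slight rise in this assay is expected, with nothing beyond the scatter, and the estimated change is a 1.4-fold higher number from compound 3 to compound 4 (0.14 log units; within the scatter) on this basis. For compound 4 the estimated value is 12000 nM with an expected range from 6000 nM to 24000 nM in this read-out.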

Compound 4, half-maximal inhibitory concentration: 26100 nM
Compound 4: the middle estimate sits 2.2-fold (0.34 log units) below what was measured; measured number above the stated range.
By their numbers in this assay, from the lowest: compounds 3, 2, 1 and 4 (each within the scatter of the next, the first and the last beyond it).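

In this assay, among the compounds shown here, 2,4-difluorobenzyl in place of 4-chlorobenzyl gives the largest step yet seen at this position (a 3.0-fold higher number from compound 3 to compound 4 (0.48 log units; beyond the scatter)), and it is the only change to the benzyl group so far that separates compound 4 from another compound. Fluoro in place of hydrogen on an aromatic carbon stays within the scatter (a 1.9-fold higher number from compound 2 to compound 4 (0.27 log units; within the scatter)), as does 2,4-difluorophenyl in place of 4-nitrophenyl (a 1.4-fold higher number from compound 1 to compound 4 (0.15 log units; within the scatter)), so compound 4 is separated from compound 3 alone. No measurement on hand accounts for this difference.

Still open, as far as these compounds go, is how much of the step from 4-chlorophenyl belongs to losing the chloro group and how much to adding the second fluoro group. The compounds shown also leave open how an amine or a longer chain at this position would read.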